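A Sulfonyl Swap Among Compounds at the Limit

This account rests on a few compounds, and the source may have more. Where it says the series, first, only, none or still open, it means among the compounds named here.

In a functional assay on HeLa cells (Homo sapiens) for cytotoxicity, read by MTT assay, with a stated time of 72 h (on this read-out higher numbers stand for weaker inhibition and lower numbers for stronger inhibition), compound 2 (`CCOC(=O)c1csc2nc(-c3ccc(NC(=O)Nc4ccc(Br)cn4)cc3)cn12`) gives > 20000 nM as a limit and not a number. Compound 1 (`CCOC(=O)c1csc2nc(-c3cccc(NC(=O)c4ccco4)c3)cn12`) gives > 20000 nM as a limit too. Compound 3 (`CCOC(=O)c1csc2nc(-c3cccc(NC(=O)CC)c3)cn12`) likewise gives > 20000 nM as a limit. Compound 2 thus stands with the other two at one shared place (the limit of > 20000 nM in this assay, at which 3 of the 3 values shown sit) and no order among them can be read.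

Compound 4 (`CCOC(=O)c1csc2nc(-c3ccc(NS(=O)(=O)c4ccc(C)cc4)cc3)cn12`) differs from compound 2 in one place ((4-methylphenyl)sulfonyl in place of (5-bromopyridin-2-yl)carbamoyl on a nitrogen on an aromatic ring): (4-methylphenyl)sulfonyl in place of (5-bromopyridin-2-yl)carbamoyl on a nitrogen on an aromatic ring. Within the data shown here, the only measured step (a step that the two limits leave unreadable from compound 1 to compound 3) puts ethyl in place of furan-2-yl on a carbonyl carbon and has no readable size, so it offers no size to carry over. With no measured number to lean on, no change beyond the scatter is expected in this assay and compound 4 is expected to stay near the limit. The expected step (a step that the limit leaves unreadable from compound 2 to compound 4) is an estimate only. For compound 4 the estimated value is 25000 nM with 10000 nM to 50000 nM as its expected range.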

Compound 4, half-maximal inhibitory concentration: > 20000 nM
Compound 4 ended at the assay's limit; the forecaster's own chance of this, stated with the estimate: 80%; the middle value does not contradict the limit.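

In this assay compound 4 gives > 20000 nM, a limit and not a number. Compound 2 sits at the same limit, so no step can be read from compound 2 to compound 4: the limit of > 20000 nM in this assay, at which 4 of the 4 values shown sit.

The compounds shown leave open which change, if any, would bring a measurable value in this read-out.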